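A few compounds are considered here, and "the series" means these few. Any claim that something is new, unique, unknown or untested is made for them only; others in the source may bear on it.

Three compounds share one core and differ only in the group carried on an aromatic carbon. Compound 1 `Cc1nc(C#Cc2cccc(Cl)c2)cs1` gives 129 nM in a functional assay on CHO cells for agonist activity at metabotropic glutamate receptor 5 (Homo sapiens), read by inositol phosphate accumulation; a lower number here means a stronger inhibitor, a higher number a weaker inhibitor. Compound 2 `Cc1nc(C#Cc2cccc(OC(F)(F)F)c2)cs1` gives 266 nM in this assay, and compound 3 `Cc1nc(C#Cc2cccc(C#N)c2)cs1` gives 0.94 nM in this assay. Compound 3 thus holds the lowest of the three numbers: there is a 140-fold lower number from compound 1 to compound 3 (2.14 log units; beyond the scatter) and a 280-fold lower number from compound 2 to compound 3 (2.45 log units; beyond the scatter), whereas a 2.1-fold higher number from compound 1 to compound 2 (0.31 log units; beyond the scatter) is only modest. Compound 4 `CC(=O)Nc1cccc(C#Cc2csc(C)n2)c1` has not yet been measured; relative to compound 3 the change is acetamido in place of cyano on an aromatic carbon. Among the measured compounds shown here, no measured step exchanges cyano for acetamido, so the three known steps bear on it only indirectly, each swapping the group on an aromatic carbon, and the one introducing cyano produced the large drop. The compounds lacking cyano gave much higher numbers, as seen in a 140-fold lower number from compound 1 to compound 3 (2.14 log units; beyond the scatter) and a 280-fold lower number from compound 2 to compound 3 (2.45 log units; beyond the scatter) read in reverse. A large rise in this assay is therefore expected for compound 4, namely a 160-fold higher number from compound 3 to compound 4 (2.20 log units; beyond the scatter). Compound 4 is estimated at 150 nM, within a range from 20 nM to 1500 nM.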

Compound 4, half-maximal inhibitory concentration: 2020 nM
Beside the measured number, compound 4's estimate is 13-fold (1.13 log units) below it; measured number above the stated range.
By their numbers in this assay, from the lowest: compound 3; then compound 1; then compound 2; then compound 4.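

In this assay, acetamido on this aromatic carbon gives a far higher number than cyano (a 2100-fold higher number from compound 3 to compound 4 (3.33 log units; beyond the scatter)), and it also stands above chloro (a 16-fold higher number from compound 1 to compound 4 (1.19 log units; beyond the scatter)) and trifluoromethoxy (a 7.6-fold higher number from compound 2 to compound 4 (0.88 log units; beyond the scatter)). The earlier compounds shown here showed cyano far below two other groups; compound 4 shows that the spread at this single position is wider still, with compound 4 the weakest of the four. The change from cyano adds heavy atoms and a hydrogen-bond donor, and this one step cannot tell which of these, if either, accounts for the rise. Nothing measured here explains the size of these steps.

Going by these compounds, how an amine, a carboxylic acid or a longer acyl chain would read at this carbon remains open. So does whether any other small group, such as an ethynyl or a fluoro, can approach the low number of compound 3.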